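The compounds below may be only part of what the source reports. "The series", "measured", "known", "first", "only" and "open" are said of these compounds alone.

In a functional assay on A-375 cells (Homo sapiens) for cytotoxicity, read by CCK-8 assay, with a stated time of 24 h (on this read-out higher numbers stand for weaker inhibition and lower numbers for stronger inhibition), compound 3 `COc1ccccc1Oc1c(N)nc(-c2ccc(Cl)cc2)nc1OCCO` gives > 80000 nM, and this is a limit of the assay, not a number. The other two measured compounds do give numbers: compound 2 `COc1ccccc1Oc1c(N)nc(Cc2ccccc2)nc1OCCO` gives 200 nM, and compound 1 `COc1ccccc1Oc1c(N)nc(-c2ccc(Br)cc2)nc1Cl` gives 63 nM. Compound 4 `COc1ccccc1Oc1c(N)nc(-c2ccc(Br)cc2)nc1OCCO` is still unmeasured and differs from compound 3 in one place: bromo in place of chloro on an aromatic carbon, para to a large group.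

Among the measured compounds shown here, no measured step makes this exact swap. The closest is an at least 400-fold higher number from compound 2 to compound 3 (2.60 log units; beyond the scatter), a large step that shows how much a change in this part of the molecule can matter. Compound 1 carries the same 4-bromophenyl group and gives 63 nM, but it also differs from compound 4 elsewhere, so it is only a weak hint. In this assay, compound 4 is therefore expected to stay weak, with some shift towards a lower number possible. The expected change is an at least 2.0-fold lower number from compound 3 to compound 4 (0.30 log units; that floor lies within the scatter). For compound 4 the estimated value is 40000 nM, with an expected range from 2000 nM to 80000 nM.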

Compound 4, half-maximal inhibitory concentration: 10300 nM
Beside the measured number, compound 4's estimate is 3.9-fold (0.59 log units) above it, and the stated range covers the measured number.
By their numbers in this assay, from the lowest: compound 1; then compound 2; then compound 4. At a limit, above all of these: compound 3.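

With 2-hydroxyethoxy held fixed, going from 4-chlorophenyl to 4-bromophenyl in this assay gives an at least 7.7-fold lower number from compound 3 to compound 4 (0.89 log units; beyond the scatter), so exchanging this one halogen atom alone can shift the result. Compound 3 stands at a limit of the assay, not at a number, so this step is only a floor: the limit of > 80000 nM in this assay, at which 1 of the 4 values shown sits. Bromo does not bring back the strength of the other two compounds, though: 4-bromophenyl in place of benzyl leaves a 52-fold higher number from compound 2 to compound 4 (1.71 log units; beyond the scatter), and 2-hydroxyethoxy in place of chloro leaves a 160-fold higher number from compound 1 to compound 4 (2.21 log units; beyond the scatter).

The compounds shown leave open how iodo, methyl or methoxy would read in place of bromo on this phenyl ring. They also leave open whether an amine or a longer chain in place of 2-hydroxyethoxy would change the number for the 4-bromophenyl compound.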